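The source may report more compounds than this note shows. Statements on the series, on what has been measured and on what is new or still open speak of the compounds shown alone.

Compound 1 `COc1cc(-c2cc(/C=C/C(=O)c3ccc(Cl)c(Cl)c3)[nH]n2)cc(OC)c1OC` gives -74% in a functional assay on SF-539 cells (Homo sapiens) for cytotoxicity, read by sulforhodamine B assay, with a stated time of 48 h, tested at 100 uM; a higher number here means a weaker effect of the compound at the concentration tested, a lower number a stronger effect.
Compound 2 `COc1ccc(C(=O)/C=C/c2cc(-c3cc(OC)c(OC)c(OC)c3)n[nH]2)cc1OC` gives -96% in this assay.
Compound 3 `COc1ccc(C(=O)/C=C/c2cc(-c3cc(OC)c(OC)c(OC)c3)n[nH]2)cc1` gives -92% in this assay.

Among these three numbers compound 3 stands second highest; its nearest neighbour is compound 2, and the gap a number 4 percentage points higher from compound 2 to compound 3 (within the scatter) lies within the scatter, while the gap to compound 1 is wider, as a number 18 percentage points lower from compound 1 to compound 3 (beyond the scatter) shows. Compound 4 `COc1cc(-c2cc(/C=C/C(=O)c3ccc(F)c(F)c3)[nH]n2)cc(OC)c1OC` differs from compound 3 in one place: 3,4-difluorophenyl in place of 4-methoxyphenyl on a carbonyl carbon. The step that bears on this is the one going the other way, a number 18 percentage points lower from compound 1 to compound 3 (beyond the scatter), together with a number 22 percentage points lower from compound 1 to compound 2 (beyond the scatter); both show that a dihalogenated phenyl group on the carbonyl carbon gave a higher number than a methoxylated one. A step upward in this assay is therefore expected for compound 4, a number 12 percentage points higher from compound 3 to compound 4 (beyond the scatter), though fluorine rather than chlorine leaves its size uncertain. Compound 4 is estimated at -80%, within -95% to -60%.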

Compound 4, a percentage reported as activity, at one concentration (the size of the read-out at that concentration, not a potency): -63%
The estimate for compound 4 lay 17 percentage points below the measured number; measured number inside the range.
By their numbers in this assay, from the lowest: compounds 2 and 3 (each within the scatter of the next); then compound 1; then compound 4.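

In this assay, the 3,4-difluorophenyl group on the carbonyl carbon gives the highest number of the set, with a number 29 percentage points higher from compound 3 to compound 4 (beyond the scatter) and a number 33 percentage points higher from compound 2 to compound 4 (beyond the scatter). The two dihalogenated groups also separate, with a number 11 percentage points higher from compound 1 to compound 4 (beyond the scatter), so the number at this position depends on which halogen is present and not only on halogen against methoxy. Nothing available explains these steps. Still open, on these data alone, is how a phenyl group carrying an amine or a carboxylic acid would read at this carbonyl carbon. Also open, as far as these compounds go, is how a phenyl group with a single fluorine would compare.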